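Adding a methoxy group to compound 1

The source may report more compounds than this note shows. Statements on the series, on what has been measured and on what is new or still open speak of the compounds shown alone.

In a functional assay on A549 cells (Homo sapiens) for antiproliferative activity, read by MTT assay, with a stated time of 72 h (on this read-out higher numbers stand for weaker inhibition and lower numbers for stronger inhibition), compound 1 `Cc1nc(C)c(/C=C/C(=O)/C=C/c2ccccc2O)nc1C` gives 4780 nM. Going by the values given here, compound 2 `Cc1nc(C)c(/C=C/C(=O)/C=C/c2cccc(O)c2)nc1C`, the only other compound measured, gives 4300 nM, so compound 1 stands level with its single neighbour. Moving the hydroxy group gave a 1.1-fold lower number from compound 1 to compound 2 (0.05 log units; within the scatter).

Compound 3 `COc1cccc(/C=C/C(=O)/C=C/c2nc(C)c(C)nc2C)c1O` differs from compound 1 by one change: methoxy in place of hydrogen on an aromatic carbon. The methoxy group stands ortho to a hydroxy group and meta to a large group. Among the compounds with values here, no measured step adds a methoxy group, so the data offer no direct guide. Within the data shown here, the one step available concerns the same ring and stayed small, which gives no reason to expect a clear shift in either direction in this assay. The expected change is a 1.2-fold lower number from compound 1 to compound 3 (0.08 log units; within the scatter), no step beyond the scatter. For compound 3 the estimated value is 4000 nM, with an expected range of 1500 nM to 10000 nM.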

Compound 3, half-maximal inhibitory concentration: 2850 nM
Compound 3: the middle estimate sits 1.4-fold (0.15 log units) above what was measured; the measured number falls inside the stated range.
By their numbers in this assay, from the lowest: compounds 3, 2 and 1 (each within the scatter of the next).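

In this assay, methoxy in place of hydrogen on this aromatic carbon, ortho to a hydroxy group and meta to a large group, gives a step that stays within the scatter (a 1.7-fold lower number from compound 1 to compound 3 (0.22 log units; within the scatter)). Compound 2 showed only what happens when the hydroxy group moves, whereas compound 3 shows that this ring can also carry an added group of 2 heavy atoms without a clear shift in the read-out. No measurement shown here explains this result.

On these data alone, it remains open whether a different group on this same carbon, such as a chlorine atom, an amine or a carboxylic acid, would give a step beyond the scatter. As far as these compounds go, it is also open whether methoxy would give a similarly small step on the ring of compound 2.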